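A Sulfonyl Group Replaces Benzyl on the Shared Core

A few compounds are considered here, and "the series" means these few. Any claim that something is new, unique, unknown or untested is made for them only; others in the source may bear on it.

Compound 1 `COc1ccc(-c2cc(=O)c3c(OC)cc(OC)cc3n2C)cc1` carries a methyl on the aromatic nitrogen of the shared core. In an ADME assay on BJ cells (Homo sapiens) for antiproliferative activity, with a stated time of 72 h (on this read-out higher numbers stand for an effect only at larger amounts of compound and lower numbers for an effect already at smaller amounts), compound 1 gives 68000 nM. Compound 2 `COc1ccc(-c2cc(=O)c3c(OC)cc(OC)cc3n2Cc2ccccc2)cc1` carries a benzyl at that nitrogen instead. In this assay compound 2 gives only the limit > 34400 nM, so no number is known for it. Compound 3 `COC(=O)c1cc(=O)c2c(OC)cc(OC)cc2n1C` keeps the methyl but carries methoxycarbonyl in place of 4-methoxyphenyl. In this assay compound 3 likewise gives only the limit > 37900 nM. The steps a step that the limit leaves unreadable from compound 1 to compound 2 and a step that the limit leaves unreadable from compound 1 to compound 3 cannot be read in size because the limit of > 34400 nM in this assay, at which 1 of the 3 values shown sits, and the limit of > 37900 nM in this assay, at which 1 of the 3 values shown sits, cap them.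

Compound 4 `COc1ccc(-c2cc(=O)c3c(OC)cc(OC)cc3n2S(=O)(=O)c2ccc(Br)s2)cc1` differs from compound 2 by (5-bromothiophen-2-yl)sulfonyl in place of benzyl on an aromatic nitrogen. Going by the values given here, no measured step covers an exchange of this kind on the aromatic nitrogen, and the two measured steps that touch this series are both unreadable. What remains is that compound 2 sits at its limit, and nothing shown argues that the new group should move the read-out far from there. The expected step is therefore a step that the limit leaves unreadable from compound 2 to compound 4, no change beyond the usual scatter. Compound 4 is estimated at 40000 nM, with a range from 15000 nM to 100000 nM, and most likely only a limit will again be recorded.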

Compound 4, half-maximal effective concentration: > 48200 nM
Compound 4 ended at the assay's limit; the forecaster's own chance of this, stated with the estimate: 65%; middle value at least 1.2-fold (0.08 log units) away from the limit.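

Compound 4 gives only a limit and no number, so the steps to it from compound 1 and from compound 2 cannot be read in size: the limit of > 48200 nM in this assay, at which 1 of the 4 values shown sits. The compounds shown leave open whether (5-bromothiophen-2-yl)sulfonyl in place of benzyl on the aromatic nitrogen changes the read-out at all, since compound 2 and compound 4 both lack a number.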